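Oxetanylmethoxy series: cyano on the oxetane methyl

The source may report more compounds than this note shows. Statements on the series, on what has been measured and on what is new or still open speak of the compounds shown alone.

Measured compounds in a functional assay on cells for antagonist activity at Free fatty acid receptor 1 (Homo sapiens), read by TR-FRET and inositol phosphate accumulation, with a stated time of 2 h; on this read-out higher numbers stand for weaker inhibition and lower numbers for stronger inhibition:
Compound 1, `Fc1ccc(OCc2cc(N3CC4(CCO4)C3)nc(-c3ccccn3)n2)c(F)c1F`, compound 1 gives 501 nM
Compound 2, `CC1(CS(C)(=O)=O)CN(c2cc(COc3ccc(F)c(F)c3F)nc(-c3ccccn3)n2)C1`, compound 2 gives 6310 nM
Compound 3, `CC1(COc2cc(COc3ccc(F)c(F)c3F)nc(-c3ccccn3)n2)COC1`, compound 3 gives 79.4 nM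

Compound 3 holds the lowest number of the three, with a 6.3-fold lower number from compound 1 to compound 3 (0.80 log units; beyond the scatter) and a 79-fold lower number from compound 2 to compound 3 (1.90 log units; beyond the scatter), both beyond the scatter, so compound 3 is the most potent antagonist shown. The other step, a 13-fold higher number from compound 1 to compound 2 (1.10 log units; beyond the scatter), is a large loss.

Compound 4, `N#CCC1(COc2cc(COc3ccc(F)c(F)c3F)nc(-c3ccccn3)n2)COC1`, differs from compound 3 only by cyano in place of hydrogen on a saturated chain carbon bound to a saturated ring carbon. For the measured compounds named here, none of the measured steps touches this change: the measured steps swap whole substituents on the aromatic carbon, while here the oxetanylmethoxy is kept and a small group is added at its methyl. Going by the values given here, the nearest precedent, compound 1 to compound 2, adds a polar group and is a large loss, but it also changes the ring, so it is only a weak guide. The expectation is a small change, if any beyond the scatter, leaning toward a higher number.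

The step from compound 3 to compound 4 is expected to be a 2.0-fold higher number from compound 3 to compound 4 (0.30 log units; within the scatter). Compound 4 is expected to give about 160 nM, within 50 nM to 500 nM.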

Compound 4, half-maximal inhibitory concentration: 398 nM
Compound 4: the middle estimate sits 2.5-fold (0.40 log units) below what was measured, within the range that was stated.
By their numbers in this assay, from the lowest: compound 3; then compounds 4 and 1 (each within the scatter of the next); then compound 2.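

In this assay, the methyl of the (3-methyloxetan-3-yl)methoxy group proves not to be a silent place: cyano in place of hydrogen on this saturated chain carbon gives a step beyond the scatter (a 5.0-fold higher number from compound 3 to compound 4 (0.70 log units; beyond the scatter)). This step removes the separation of compound 3 from compound 1, since compound 4 and compound 1 stand within the scatter of each other (a 1.3-fold lower number from compound 1 to compound 4 (0.10 log units; within the scatter)), yet the cyanomethyl compound stays clearly on the stronger side of the sulfone-bearing azetidine (a 16-fold lower number from compound 2 to compound 4 (1.20 log units; beyond the scatter)). No supporting data speak to the origin of this shift.

The compounds shown leave open whether the step belongs to cyano itself or to any addition at this carbon. An ethyl, fluoromethyl or hydroxymethyl group in place of the methyl would bear on that question.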